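Swapping a branched alkyl for an aryl ether

A few compounds are considered here, and "the series" means these few. Any claim that something is new, unique, unknown or untested is made for them only; others in the source may bear on it.

Compound 2 `CCC(CC)c1ccc2c(NCCCNCc3ccco3)ccnc2c1` gives 9.47 in a physicochemical assay for acid dissociation. Compound 1 `Cc1cc(C)cc(Cc2ccc3c(NCCCNCc4ccco4)ccnc3c2)c1` in this assay gives 9.47, and the step from compound 1 to compound 2, which exchanges one group on an aromatic carbon for another, is no change at the digits printed from compound 1 to compound 2 (within the scatter). Compound 2 therefore stands level with compound 1 at the digits shown, the two lying within the scatter of each other. Compound 3 `COc1ccc(Oc2ccc3c(NCCCNCc4ccco4)ccnc3c2)cc1` has not yet been measured. The change from compound 2 to compound 3 is 4-methoxyphenoxy in place of pentan-3-yl on an aromatic carbon. Among the measured compounds shown here, the only measured step at this same place, on an aromatic carbon that is part of a fused or bridged system of two rings, is the one from compound 1 to compound 2, and it left the value unchanged within the scatter. For the measured compounds named here, only that single step is available to lean on. On that basis compound 3 is expected to give about 9.45, within a range from 9.1 to 9.8. The estimated step of a number 0.02 log units lower from compound 2 to compound 3 (within the scatter) is expected to stay within the scatter.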

Compound 3, acid dissociation constant: 9.28
Beside the measured number, compound 3's estimate is 0.17 log units above it, and the stated range covers the measured number.
By their numbers in this assay, from the lowest: compounds 3, 1 and 2 (each within the scatter of the next).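

In this assay, 4-methoxyphenoxy on this aromatic carbon, which carries oxygen and hydrogen-bond acceptors that pentan-3-yl lacks, gives a number 0.19 log units lower from compound 2 to compound 3 (within the scatter) and, in place of 3,5-dimethylbenzyl, gives a number 0.19 log units lower from compound 1 to compound 3 (within the scatter). Across compounds 1, 2 and 3, then, three quite different groups at this place leave this assay within the scatter, and no compound shown goes against this, so the level seen for the first two compounds also holds for a group joined through oxygen. No available measurement offers an explanation for this result.

The compounds shown leave open whether a group of another kind on this carbon, such as an amine or a carboxylic acid, would move the value beyond the scatter. They also do not show which atom of these molecules gives up the proton.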